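This account rests on a few compounds, and the source may have more. Where it says the series, first, only, none or still open, it means among the compounds named here.

Compound 1, `Cn1nc2c(=O)n(CC3(O)CCN(Cc4ccc(-c5ccco5)cc4Cl)CC3)cnc2c1-c1ccc(CNC(=O)C(F)(F)F)cc1`, gives 2060 nM in an assay on isolated protein for inhibition of ubiquitin carboxyl-terminal hydrolase 7 (Homo sapiens), with stated times of 30 min and 2 h; on this read-out higher numbers stand for weaker inhibition and lower numbers for stronger inhibition.
Compound 2, `CC(C)NCc1ccc(-c2c3ncn(CC4(O)CCN(Cc5ccc(-c6ccco6)cc5Cl)CC4)c(=O)c3nn2C)cc1`, gives 29.1 nM.
Compound 3, `Cn1nc2c(=O)n(CC3(O)CCN(Cc4ccc(-c5ccco5)cc4Cl)CC3)cnc2c1-c1ccc(C2(N)CC2)cc1`, gives 66.1 nM.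

Among these three numbers compound 3 stands second highest: it sits far from compound 1, as the step of a 31-fold lower number from compound 1 to compound 3 (1.49 log units; beyond the scatter) shows, and close to compound 2, as the modest step of a 2.3-fold higher number from compound 2 to compound 3 (0.36 log units; beyond the scatter) shows. Compound 4, `Cn1nc2c(=O)n(CC3(O)CCN(Cc4ccc(-c5ccco5)cc4Cl)CC3)cnc2c1-c1ccc(CNCCO)cc1`, differs from compound 3 in one place: ((2-hydroxyethyl)amino)methyl in place of 1-aminocyclopropyl on an aromatic carbon. Among the compounds with values here, two measured steps bear on this change. The large steps of a 71-fold lower number from compound 1 to compound 2 (1.85 log units; beyond the scatter) and a 31-fold lower number from compound 1 to compound 3 (1.49 log units; beyond the scatter) both show that replacing the (trifluoromethyl)carbonyl amide with a plain amine lowers the number greatly, while the smaller step of a 2.3-fold higher number from compound 2 to compound 3 (0.36 log units; beyond the scatter) shows that two different plain amines land near each other. Compound 4 keeps a plain amine on a methylene, much as compound 2 does, with a 2-hydroxyethyl where compound 2 carries an isopropyl. The expected step of a 1.7-fold lower number from compound 3 to compound 4 (0.22 log units; within the scatter) is therefore small, leaning toward a lower number but likely within the scatter. The estimate for compound 4 is 40 nM, with a range from 15 nM to 120 nM.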

Compound 4, half-maximal inhibitory concentration: 8.2 nM
For compound 4 the middle estimate is 4.9-fold (0.69 log units) above the measured one, outside the stated range (below it).
By their numbers in this assay, from the lowest: compound 4; then compound 2; then compound 3; then compound 1.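

In this assay, the group on the amine nitrogen still matters once the amide of compound 1 is gone: 2-hydroxyethyl in place of isopropyl gives a 3.5-fold lower number from compound 2 to compound 4 (0.55 log units; beyond the scatter) and so separates two plain amines that had seemed to land close together. On the aromatic carbon para to a large group, the change from 1-aminocyclopropyl to ((2-hydroxyethyl)amino)methyl gives an 8.1-fold lower number from compound 3 to compound 4 (0.91 log units; beyond the scatter), while the widest step in the set, a 250-fold lower number from compound 1 to compound 4 (2.40 log units; beyond the scatter), makes compound 4 the strongest inhibitor of the four, with its steps to all the others beyond the scatter. Nothing measured here explains why this chain gives the lowest number.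

On these data alone, it remains open whether the hydroxyl itself counts, since a plain ethyl or a 2-methoxyethyl on the same nitrogen would be needed to tell. As far as these compounds go, how a longer 3-hydroxypropyl chain or a carboxylic acid at the chain end would compare also remains unknown.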